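A few compounds are considered here, and "the series" means these few. Any claim that something is new, unique, unknown or untested is made for them only; others in the source may bear on it.

In a functional assay on MIA PaCa-2 cells (Homo sapiens) for antiproliferative activity, read by sulforhodamine B assay, with a stated time of 48 h (on this read-out lower numbers stand for stronger inhibition and higher numbers for weaker inhibition), compound 3 (`COc1cc(C(=O)/C=C\Nc2ccc(-c3nc4cc(OC)c(OC)c(OC)c4s3)cc2)cc([N+](=O)[O-])c1OC`) gives 15800 nM, within the scatter of compound 2 (`COc1cc(OC)c2sc(-c3ccc(N/C=C\C(=O)c4cc(OC)c(OC)c(OC)c4)cc3)nc2c1`) at 26800 nM and clearly above compound 1 (`COc1cc(OC)c2sc(-c3ccc(N/C=C\C(=O)c4ccc(OC)c([N+](=O)[O-])c4)cc3)nc2c1`) at 2900 nM. Compound 4 (`COc1cc(OC)c2sc(-c3ccc(N/C=C\C(=O)c4cc(OC)c(OC)c([N+](=O)[O-])c4)cc3)nc2c1`) differs from compound 3 by hydrogen in place of methoxy on an aromatic carbon, (hydrogen in place of methoxy on an aromatic carbon). Within the data shown here, no measured step covers that change. Among the measured compounds shown here, the only measured step is modest and lies elsewhere, at the carbonyl carbon, where 3,4,5-trimethoxyphenyl replaces 4-methoxy-3-nitrophenyl. Compound 4 shares the core of compound 1 and compound 2, and its ring on the carbonyl carries both methoxy and nitro groups, so a value inside the span of a 9.2-fold higher number from compound 1 to compound 2 (0.97 log units; beyond the scatter) is expected in this assay. The expected change, a 1.8-fold lower number from compound 3 to compound 4 (0.24 log units; within the scatter), is no step beyond the scatter. Compound 4 is estimated at 9000 nM, with an expected range from 3000 nM to 26000 nM.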

Compound 4, half-maximal inhibitory concentration: 12700 nM
Compound 4: the middle estimate sits 1.4-fold (0.15 log units) below what was measured; the measured number falls inside the stated range.
By their numbers in this assay, from the lowest: compound 1; then compounds 4, 3 and 2 (each within the scatter of the next, the first and the last beyond it).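

In this assay, hydrogen in place of methoxy on the fused ring of the shared core gives a 1.2-fold lower number from compound 3 to compound 4 (0.09 log units; within the scatter), so this position shows no change beyond the scatter between these two groups. The ring on the carbonyl does show such changes: nitro in place of methoxy gives a 2.1-fold lower number from compound 2 to compound 4 (0.32 log units; beyond the scatter), and methoxy in place of hydrogen gives a 4.4-fold higher number from compound 1 to compound 4 (0.64 log units; beyond the scatter). Nothing available explains these steps. On these data alone, whether an amine or fluorine at the core position would match hydrogen and methoxy remains open. So does the effect of a carboxylic acid in place of nitro on the ring on the carbonyl.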